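From Benzylamino to Aminopropyl: What Compound 4 May Give

The source may report more compounds than this note shows. Statements on the series, on what has been measured and on what is new or still open speak of the compounds shown alone.

Measured so far:
compound 1, `O=C(NCc1ccc(F)cc1)c1nc(Br)c2cccnc2c1NCCCNc1c(C(=O)NCc2ccc(F)cc2)nc(Br)c2cccnc12`: > 20000 nM
compound 2, `O=C(NCc1ccc(F)cc1)c1nc(Br)c2cccnc2c1NCc1ccccc1`: > 20000 nM
compound 3, `C[C@@H](CO)Nc1nc(C(=O)NCc2ccc(F)cc2)c(O)c2ncccc12`: "not determined" (no result reported)

Three compounds have been examined in a functional assay on HCT-116 cells (Homo sapiens) for cytotoxicity, read by MTT assay, with a stated time of 72 h; on this read-out lower numbers stand for stronger inhibition and higher numbers for weaker inhibition. Compound 1 `O=C(NCc1ccc(F)cc1)c1nc(Br)c2cccnc2c1NCCCNc1c(C(=O)NCc2ccc(F)cc2)nc(Br)c2cccnc12` reports only a limit of the assay, > 20000 nM, and not a number. Compound 2 `O=C(NCc1ccc(F)cc1)c1nc(Br)c2cccnc2c1NCc1ccccc1` likewise reports only a limit, > 20000 nM. For compound 3 `C[C@@H](CO)Nc1nc(C(=O)NCc2ccc(F)cc2)c(O)c2ncccc12` no result is reported in this assay, "not determined" (no result reported). Compound 2 therefore stands at the limit, where two of the three entries sit; this is summarised as the limit of > 20000 nM in this assay, at which 2 of the 3 values shown sit.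

The account follows the step from compound 2 to compound 4 `CNCCCNc1c(C(=O)NCc2ccc(F)cc2)nc(Br)c2cccnc12`. The difference, counted from the two structures, is 2-(methylamino)ethyl in place of phenyl on a saturated chain carbon bound to a nitrogen on an aromatic ring. Among the compounds with values here, with no step between two measured compounds available, the size of this change in this assay cannot be read from any pair; the only anchor is that compound 2 gives no number at all.

Compound 4 is expected to remain weak, so that the step from compound 2 to compound 4 is estimated as an at least 1.3-fold lower number from compound 2 to compound 4 (0.12 log units; that floor lies within the scatter), with a fair chance that only a limit is again reported. The estimate for compound 4 is 15000 nM, within 4000 nM to 40000 nM.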

Compound 4, half-maximal inhibitory concentration: > 10000 nM
Compound 4: no number, only a limit; the forecaster's own chance of this, stated with the estimate: 55%; the middle value lies beyond the limit too.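

In this assay compound 4 reports only a limit, > 10000 nM. Within the data shown here, compound 2 also reports only a limit, so no step from compound 2 to compound 4 can be read. The compounds shown leave open whether benzylamino to (3-(methylamino)propyl)amino changes the read-out at all, and if so, in which direction and by how much.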